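Amine Variation on a Shared Core in a Cell Assay

A few compounds are considered here, and "the series" means these few. Any claim that something is new, unique, unknown or untested is made for them only; others in the source may bear on it.

compound 1 `O=C1C=C(NCc2ccccc2)C(=O)c2c1nc1n2[C@H]2OC[C@@H](O)[C@H]2OC1` — > 8000 nM, a limit
compound 2 `COc1ccc(NC2=CC(=O)c3nc4n(c3C2=O)[C@H]2OC[C@@H](O)[C@H]2OC4)cc1` — > 4000 nM, a limit

In a functional assay on ECa-109 cells for inhibition, with ECa-109 cell line (Homo sapiens) as the target, read by sulforhodamine B assay (on this read-out lower numbers stand for stronger inhibition and higher numbers for weaker inhibition), compound 1 gives > 8000 nM, a limit of the assay rather than a number. Compound 2 gives > 4000 nM in this assay, again only a limit. Within the data shown here, compound 2 therefore stands at a limit, and the single measured step, a step that the two limits leave unreadable from compound 1 to compound 2, stays unreadable: the limit of > 4000 nM in this assay, at which 1 of the 2 values shown sits, and the limit of > 8000 nM in this assay, at which 1 of the 2 values shown sits, are both limits. Compound 3 `O=C1C=C(N2CCCC2)C(=O)c2c1nc1n2[C@H]2OC[C@@H](O)[C@H]2OC1` carries the change (pyrrolidin-1-yl in place of (4-methoxyphenyl)amino on a double-bonded ring carbon). Among the measured compounds shown here, no measured step bears on this change, so no direction is expected beyond the scatter. Compound 3 is expected to give 6000 nM, between 1500 nM and 30000 nM. That estimate means an expected step that the limit leaves unreadable from compound 2 to compound 3.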

Compound 3, half-maximal inhibitory concentration: > 16000 nM
Compound 3 gave a limit, no number; the forecaster's own chance of this, stated with the estimate: 60%; at least 2.6-fold (0.42 log units) between middle value and limit.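

In this assay compound 3 gives > 16000 nM, a limit and not a number. Among these compounds, no step among compound 1, compound 2 and compound 3 can be read. The compounds shown leave open how the benzylamino, (4-methoxyphenyl)amino and pyrrolidin-1-yl groups rank against one another.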